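Bromo-salicylanilide series: hydroxy methylation and cytotoxicity

This account rests on a few compounds, and the source may have more. Where it says the series, first, only, none or still open, it means among the compounds named here.

Measured compounds:
compound 1 `O=C(Nc1cccc(Cl)c1)c1cc(Br)cc(Br)c1O`: 18000 nM
compound 2 `COc1c(Br)cc(Br)cc1C(=O)Nc1cccc(Cl)c1`: > 100000 nM
compound 3 `O=C(Nc1cccc(Cl)c1)c1cc(Br)ccc1O`: 15000 nM

In an ADME assay on HEK293 cells (Homo sapiens) for cytotoxicity, read by reporter gene assay and resazurin assay, with a stated time of 48 h (on this read-out higher numbers stand for lower toxicity in this test and lower numbers for higher toxicity in this test), compound 1 gives 18000 nM and compound 3 gives 15000 nM. For compound 2 the assay returns only a limit, > 100000 nM, not a number. Compound 2 differs from compound 1 by methyl in place of hydrogen on an oxygen on an aromatic ring; the step is an at least 5.5-fold higher number from compound 1 to compound 2 (0.74 log units; beyond the scatter), its size bounded by the limit of > 100000 nM in this assay, at which 1 of the 3 values shown sits. Compound 3 differs from compound 1 by hydrogen in place of bromo on an aromatic carbon, and the step is a 1.2-fold lower number from compound 1 to compound 3 (0.08 log units; within the scatter), so the two hydroxy compounds sit together.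

Compound 4 `COc1ccc(Br)cc1C(=O)Nc1cccc(Cl)c1` has not yet been measured. It differs from compound 3 by methyl in place of hydrogen on an oxygen on an aromatic ring, the same change as that between compound 1 and compound 2, made on the same place. Since compound 3 stands close to compound 1 and the earlier step was an at least 5.5-fold higher number from compound 1 to compound 2 (0.74 log units; beyond the scatter), a step of comparable size is expected, a 5.3-fold higher number from compound 3 to compound 4 (0.73 log units; beyond the scatter). Compound 4 is therefore estimated at 80000 nM, between 25000 nM and 200000 nM, with a real chance that only a limit is reported.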

Compound 4, half-maximal cytotoxic concentration: > 100000 nM
Compound 4 was reported as a limit; the forecaster's own chance of this, stated with the estimate: 60%; middle value at least 1.2-fold (0.09 log units) from the limit.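

In this assay the change from hydroxy to methoxy gives a higher number on both cores, with an at least 6.6-fold higher number from compound 3 to compound 4 (0.82 log units; beyond the scatter), so in these two pairs the direction carries from one core to the other: the same change on two cores in this assay, an at least 5.5-fold higher number (0.74 log units; beyond the scatter) from compound 1 to compound 2 and an at least 6.6-fold higher number (0.82 log units; beyond the scatter) from compound 3 to compound 4; the limit leaves it open whether they differ Compound 4 gives > 100000 nM, which is a limit of the assay and not a number. The size of the change on either core is therefore not shown, nor whether it is larger on one core than on the other, and the step between compound 2 and compound 4 cannot be read: the limit of > 100000 nM in this assay, at which 2 of the 4 values shown sit.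

Only methyl appears on this oxygen in the compounds shown, so it stays open whether an ethyl group, a longer chain or an acetyl group would give a step in the same direction. From the compounds shown here alone, it also stays open whether the step would carry to a core in which the chloro group gives way to a trifluoromethyl group or an amine.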